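The source may hold more compounds than are shown below. What is called first, only, known or untested is meant among the compounds shown, and "the series" means these compounds.

Measured so far in a functional assay on MT4 cells (Homo sapiens) for antiproliferative activity, read by MTT assay, with a stated time of 96 h; a higher number here means a weaker inhibitor, a lower number a stronger inhibitor:
compound 1, `CCCc1ccc(N2C(=O)NC3(CSC4=C3C(=O)c3ncccc3C4=O)C2=O)cc1`: 1 nM
compound 2, `O=C1C2=C(C(=O)c3ncccc31)C1(CS2)NC(=O)N(c2ccc(Cl)cc2)C1=O`: 10 nM
compound 3, `CCc1ccc(N2C(=O)NC3(CSC4=C3C(=O)c3ncccc3C4=O)C2=O)cc1`: 1 nM

Compound 3 stands level with compound 1 at the digits shown, and together they hold the lowest numbers of the three. Between compound 1 and compound 3 there is only no change at the digits printed from compound 1 to compound 3 (within the scatter). Compound 2 is the furthest from compound 3, with a 10-fold lower number from compound 2 to compound 3 (1.00 log units; beyond the scatter).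

Compound 4 is `CC(C)(C)c1ccc(N2C(=O)NC3(CSC4=C3C(=O)c3ncccc3C4=O)C2=O)cc1`. It differs from compound 3 by tert-butyl in place of ethyl on an aromatic carbon.

Among the compounds with values here, two measured steps bear on this change, both at the same aromatic carbon. no change at the digits printed from compound 1 to compound 3 (within the scatter) shows that adding or removing one chain carbon of the alkyl group leaves the number where it is. a 10-fold lower number from compound 2 to compound 3 (1.00 log units; beyond the scatter) shows that an alkyl group at this carbon gives a lower number than chloro. Within the data shown here, no measured step covers a branched alkyl group here, so the expectation rests on the tolerance seen for the chain length alone. For compound 4 the expected step in this assay is therefore a 2.0-fold higher number from compound 3 to compound 4 (0.30 log units; within the scatter), with the uncertainty leaning toward a somewhat higher number. Compound 4 is estimated at 2 nM, with a range from 0.5 nM to 10 nM.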

Compound 4, half-maximal inhibitory concentration: 200 nM
For compound 4 the middle estimate is 100-fold (2.00 log units) below the measured one; measured number outside the range, above it.
By their numbers in this assay, from the lowest: compounds 1 and 3 (each within the scatter of the next); then compound 2; then compound 4.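

In this assay the tolerance seen between ethyl and propyl does not extend to tert-butyl: the change to the branched group gives a 200-fold higher number from compound 3 to compound 4 (2.30 log units; beyond the scatter) and, against the propyl compound, a 200-fold higher number from compound 1 to compound 4 (2.30 log units; beyond the scatter) at the same aromatic carbon. The earlier reading that an alkyl group here gives a lower number than chloro holds for ethyl and propyl only, and tert-butyl goes against it with a 20-fold higher number from compound 2 to compound 4 (1.30 log units; beyond the scatter) on the same comparison. Nothing at hand accounts for this jump.

As far as these compounds go, whether the jump follows the branching or the carbon count stays open, and an isopropyl group or a straight butyl chain at this carbon would separate the two. Where an amine or a carboxylic acid at this carbon would fall relative to the alkyl and chloro compounds is also open.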